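Cytotoxicity notes on the arylidene imide amide series

A few compounds are considered here, and "the series" means these few. Any claim that something is new, unique, unknown or untested is made for them only; others in the source may bear on it.

The series shares one core, carried unchanged from compound 1 `CCCCCN1C(=O)C/C(=C\c2cccc(C(=O)Nc3cccc(CC)c3)c2)C1=O` through compound 2 `COc1ccc(OC)c(NC(=O)c2cccc(/C=C3\CC(=O)N(c4ccccc4)C3=O)c2)c1` and compound 3 `COc1cc(NC(=O)c2cccc(/C=C3\CC(=O)N(c4ccccc4)C3=O)c2)cc(OC)c1OC`, with variation only on the amide-bearing aryl group. In an ADME assay on SW480 cells (Homo sapiens) for cytotoxicity, read by MTT assay, with a stated time of 72 h (on this read-out lower numbers stand for stronger inhibition and higher numbers for weaker inhibition), compound 1 gives 83300 nM. For compound 2 the assay reports only a limit, > 100000 nM, and not a number. Compound 3 likewise reaches only a limit, > 100000 nM. Compound 2 therefore stands at the weak end of what is recorded, and the group it sits in is described by the observation (the limit of > 100000 nM in this assay, at which 2 of the 3 values shown sit); no value for compound 2 can be distinguished from that of compound 3 on these numbers, and against compound 1 the gap cannot be sized because compound 2 is at a limit.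

Compound 4 `O=C(Nc1cccc(F)c1)c1cccc(/C=C2\CC(=O)N(c3ccccc3)C2=O)c1` has not been measured. It differs from compound 2 as follows: 3-fluorophenyl in place of 2,5-dimethoxyphenyl on an amide-type nitrogen. Among the compounds with values here, no measured pair in the set reproduces this change, so its effect is not known from the data. The expectation is that the step from compound 2 to compound 4 in this assay stays within the scatter, a number no higher from compound 2 to compound 4 (the limit leaves the size open), with no clear direction. Compound 4 is accordingly estimated at 100000 nM, in the range 40000 nM to 250000 nM, with a fair chance that the assay again returns only a limit.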

Compound 4, half-maximal inhibitory concentration: > 100000 nM
Compound 4 gave a limit, no number (the forecaster's own chance of this, stated with the estimate: 60%); the middle value sits exactly at the limit.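

In this assay, within the data shown here, compound 2 and compound 4 each return a limit and not a number, so no step between them can be read. The compounds shown leave open whether 3-fluorophenyl in place of 2,5-dimethoxyphenyl on an amide-type nitrogen changes the cytotoxicity at all, with most of the series at one limit: the limit of > 100000 nM in this assay, at which 3 of the 4 values shown sit.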